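Carbonyl substituent swap from compound 3 to compound 4

This account rests on a few compounds, and the source may have more. Where it says the series, first, only, none or still open, it means among the compounds named here.

For the measured compounds named here, in a functional assay on Caco-2 cells (Homo sapiens) for antiproliferative activity, read by MTT assay, with a stated time of 48 h (on this read-out lower numbers stand for stronger inhibition and higher numbers for weaker inhibition), compound 1 (`CCn1c(C(=O)NCCN(C)C)ccc1C(CC)(CC)c1ccc(OCCC(O)(CC)CC)c(C)c1`) gives 1140 nM and is the only compound here with a readable number. Compound 2 (`CCn1c(C(=O)Nc2ccc(OC(F)(F)F)cc2)ccc1C(CC)(CC)c1ccc(OCCC(O)(CC)CC)c(C)c1`) reads > 50000 nM (a limit of the assay, not a number). Compound 3 (`CCC(C)C(NC(=O)c1ccc(C(CC)(CC)c2ccc(OCCC(O)(CC)CC)c(C)c2)n1CC)C(=O)OC`) reads > 50000 nM (also a limit of the assay, not a number). Compound 2 and compound 3 thus share the limit of > 50000 nM in this assay, at which 2 of the 3 values shown sit, and cannot be ordered against each other.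

Compound 4 (`CCn1c(C(=O)N(C)CC(=O)O)ccc1C(CC)(CC)c1ccc(OCCC(O)(CC)CC)c(C)c1`) is reached from compound 3 by one change: a group of 6 heavy atoms (3 carbon, 1 nitrogen, 2 oxygen; no ring) in place of a group of 10 heavy atoms (7 carbon, 1 nitrogen, 2 oxygen; no ring), on a carbonyl carbon. The entering group is (carboxymethyl)(methyl)amino, with no net charge.

Going by the values given here, two measured steps bear on this change, and both are large and beyond the scatter. One is an at least 43-fold higher number from compound 1 to compound 2 (1.64 log units; beyond the scatter) and the other is an at least 43-fold higher number from compound 1 to compound 3 (1.64 log units; beyond the scatter), each replacing the 2-(dimethylamino)ethyl group of compound 1. Compound 4 also lacks that group, so it is expected to stay with compound 2 and compound 3 rather than move towards compound 1. Among the compounds with values here, no measured step starts from a limit, so the size of this step remains an expectation only.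

The expected outcome in this assay is an at least 1.4-fold lower number from compound 3 to compound 4 (0.15 log units; that floor lies within the scatter), with no large gain. For compound 4 the estimated value is 35000 nM, with an expected range of 7000 nM to 50000 nM, and a reading at the limit is quite possible.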

Compound 4, half-maximal inhibitory concentration: 2740 nM
The estimate for compound 4 lay 13-fold (1.11 log units) above the measured number; measured number below the stated range.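

In this assay, compound 4 shows that a readable number at this carbonyl carbon does not depend on the (2-(dimethylamino)ethyl)amino group: with (carboxymethyl)(methyl)amino in its place, the series shows a 2.4-fold higher number from compound 1 to compound 4 (0.38 log units; beyond the scatter), a modest change beside the earlier replacements, an at least 43-fold higher number from compound 1 to compound 2 (1.64 log units; beyond the scatter) and an at least 43-fold higher number from compound 1 to compound 3 (1.64 log units; beyond the scatter). The same entering group, which has no net charge, gives an at least 18-fold lower number from compound 3 to compound 4 (1.26 log units; beyond the scatter) and an at least 18-fold lower number from compound 2 to compound 4 (1.26 log units; beyond the scatter), so the substituent on this carbonyl carbon decides whether the read-out leaves the limit, and it does so for more than one kind of group. Both of these large steps are floors and not measured gaps, as each starts from a shared limit of the assay: the limit of > 50000 nM in this assay, at which 2 of the 4 values shown sit.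

The compounds shown leave open whether the step to compound 4 follows the carboxylic acid, the methyl on the amide nitrogen or the shorter chain, and a (carboxymethyl)amino group or a (2-methoxy-2-oxoethyl)(methyl)amino group would separate these. From the compounds shown here alone, it also stays open whether a longer acid chain, such as (2-carboxyethyl)(methyl)amino, holds the number seen for compound 4.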